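The source may hold more compounds than are shown below. What is called first, only, known or untested is meant among the compounds shown, and "the series" means these compounds.

Of the compounds shown here, three built on a shared core have been measured in a functional assay on HCT-116 cells (Homo sapiens) for inhibition, read by MTT assay, with a stated time of 48 h; on this read-out lower numbers stand for stronger inhibition and higher numbers for weaker inhibition. In that test, compound 1 `Cc1nnsc1CO/N=C/c1c(C)nn(C)c1Oc1cccc(C(F)(F)F)c1` gives 10300 nM. Compound 2 `Cc1nnsc1CO/N=C/c1c(C)nn(C)c1Oc1ccc(Br)cc1` gives 7190 nM, so these two numbers lie within the usual scatter of each other, and no order can be drawn between them. Compound 3 `Cc1nnsc1CO/N=C/c1c(C)nn(C)c1Oc1ccccc1OC(F)(F)F` gives > 50000 nM, which is a limit of the assay and not a number.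

Among the compounds with values here, compound 2 therefore stands level with compound 1, as one of only two compounds with a true number. The next compound, compound 4 `Cc1nnsc1CO/N=C/c1c(C)nn(C)c1Oc1cc(F)cc(F)c1`, has not yet been measured. It carries 3,5-difluorophenyl in place of 4-bromophenyl on an oxygen on an aromatic ring. Within the data shown here, no measured pair shows this exchange directly, so the expectation rests on the values of the neighbouring compounds. Compound 2 at 7190 nM and compound 1 at 10300 nM suggest a number of similar size. The estimated step in this assay a 1.5-fold higher number from compound 2 to compound 4 (0.18 log units; within the scatter) is small, leans toward a higher number and is expected to stay close to the scatter. The range is kept wide toward higher numbers, with compound 3 at its limit of > 50000 nM in view. Compound 4 is expected to give 11000 nM, with an estimated range of 3500 nM to 35000 nM.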

Compound 4, half-maximal inhibitory concentration: 8120 nM
Beside the measured number, compound 4's estimate is 1.4-fold (0.13 log units) above it, and the stated range covers the measured number.
By their numbers in this assay, from the lowest: compounds 2, 4 and 1 (each within the scatter of the next). At a limit, above all of these: compound 3.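

In this assay, within the data shown here, 3,5-difluorophenyl in place of 4-bromophenyl on an oxygen on an aromatic ring gives a 1.1-fold higher number from compound 2 to compound 4 (0.05 log units; within the scatter) and so offers the first direct reading of an exchange at this position: the two groups cannot be told apart, although they differ in both their halogen and where it sits on the ring. With compound 4 added, three different substituted phenyl groups on this oxygen give true numbers, in compounds 1, 2 and 4, each within the scatter of the next, a pattern that compound 3 goes against. Nothing measured in this set gives a reason for this closeness.

From the compounds shown here alone, compound 3 gives > 50000 nM, which is a limit of the assay and not a number, so the size of its gap from the other three compounds stays open. The compounds shown also leave open how this position responds when the phenyl ring carries an amine or a carboxylic acid, or when a longer carbon chain takes the place of the ring.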